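Methoxy for hydroxymethyl on the cyclohexyl ring

A few compounds are considered here, and "the series" means these few. Any claim that something is new, unique, unknown or untested is made for them only; others in the source may bear on it.

Measured compounds:
compound 1, `Nc1ncnc2c1c(Oc1cc(C(F)(F)F)ccn1)nn2[C@@H]1CCCC[C@H]1O`, > 2.41 h
compound 2, `Nc1ncnc2c1c(Oc1cc(C(F)(F)F)ccn1)nn2[C@H]1CC[C@@H](CO)CC1`, 1.6 h
compound 3, `N#Cc1ccnc(Oc2nn([C@H]3C[C@H](O)C3)c3ncnc(N)c23)c1`, > 2.41 h

In an ADME assay on microsomes from liver (Homo sapiens) for metabolic stability, read by LC-MS, using NADPH, with a stated time of 10 min, tested at 10 uM (a higher number here means that the compound lasts longer, a lower number that the compound disappears faster), compound 1 reaches a limit of the assay, > 2.41 h. Compound 3 likewise reaches a limit, > 2.41 h. Compound 2 is the only one of the three with a number rather than a limit, 1.6 h, so it is also the only firm anchor for the step that follows. Among the measured compounds shown here, the one measured step, an at least 1.5-fold lower number from compound 1 to compound 2 (0.17 log units; that floor lies within the scatter), runs into the limit of > 2.41 h in this assay, at which 2 of the 3 values shown sit, and tells only that compound 2 is shorter-lived than that floor, and its size is within the usual scatter.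

Compound 4, `CO[C@H]1CC[C@@H](n2nc(Oc3cc(C(F)(F)F)ccn3)c3c(N)ncnc32)CC1`, differs from compound 2 by methoxy in place of hydroxymethyl on a saturated ring carbon. For the measured compounds named here, no measured step touches this exact exchange, and the hydroxymethyl group itself enters the data only through the step from compound 1 to compound 2, which gives no direction for its replacement. Compound 4 is therefore expected to show no step beyond the scatter, a 1.1-fold lower number from compound 2 to compound 4 (0.03 log units; within the scatter). Compound 4 is estimated at 1.5 h, between 0.7 h and 2.41 h.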

Compound 4, half-life: 0.317 h
The estimate for compound 4 lay 4.7-fold (0.68 log units) above the measured number, outside the stated range (below it).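

In this assay, the exchange at this saturated ring carbon has a clear effect, with a 5.0-fold lower number from compound 2 to compound 4 (0.70 log units; beyond the scatter), although hydroxymethyl and methoxy have the same heavy atoms and the count changes only by the hydrogen-bond donor that leaves. The earlier step on this ring stayed within the scatter at its floor, whereas the change to 4-methoxycyclohexyl from 2-hydroxycyclohexyl now gives an at least 7.6-fold lower number from compound 1 to compound 4 (0.88 log units; beyond the scatter). That second size is only a floor, because compound 1 stands at a limit of the assay: the limit of > 2.41 h in this assay, at which 2 of the 4 values shown sit.

The compounds shown leave open whether the shorter half-life follows the loss of the donor or the different joining of the same atoms. As far as these compounds go, a hydroxyl or a methoxymethyl group on this ring carbon would separate these two readings, and how an amine there would behave is equally open.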